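Pyrrolidine nitrogen substituent: benzyl replacing 3,3-dimethylbutyl

The source may report more compounds than this note shows. Statements on the series, on what has been measured and on what is new or still open speak of the compounds shown alone.

The series shares one core, carried unchanged from compound 1 `CC(C)(C)OC(=O)N1CCC[C@H]1C(=O)N1CCC(NS(=O)(=O)c2cc(S(=O)(=O)c3ccccc3)ccc2C(F)(F)F)CC1` through compound 2 `CC(C)(C)CCN1CCC[C@H]1C(=O)N1CCC(NS(=O)(=O)c2cc(S(=O)(=O)c3ccccc3)ccc2C(F)(F)F)CC1` to the unmeasured compound 3 `O=C([C@@H]1CCCN1Cc1ccccc1)N1CCC(NS(=O)(=O)c2cc(S(=O)(=O)c3ccccc3)ccc2C(F)(F)F)CC1`. In a functional assay on U2OS cells for antagonist activity at proto-oncogene Wnt-3 (Homo sapiens), read by a luciferase reporter, with a stated time of 18 h (a higher number here means that more compound is needed for the effect, a lower number that less compound is needed), compound 1 gives 60 nM, while compound 2 gives 450 nM. Among the compounds with values here, compound 2 thus stands at the highest of the two numbers seen so far, with compound 1 its only neighbour, and the single measured step, a 7.5-fold higher number from compound 1 to compound 2 (0.88 log units; beyond the scatter), shows that what sits on the amine nitrogen in the ring does move the read-out.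

The change to compound 3 is phenyl in place of neopentyl on a saturated chain carbon bound to an amine nitrogen in a ring. Within the data shown here, no measured step covers an aromatic group in this place; the one step available, from the carbamate to the 3,3-dimethylbutyl chain, is of a different kind and gives only a sense of the scale at which this position answers. With both groups of similar size and neither carrying a donor or acceptor, no large movement is foreseen. Compound 3 is therefore expected near 300 nM, with a range from 100 nM to 900 nM. This amounts to an expected step of a 1.5-fold lower number from compound 2 to compound 3 (0.18 log units; within the scatter).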

Compound 3, half-maximal effective concentration: 720 nM
Estimate against measurement, compound 3: 2.4-fold (0.38 log units) below; the range from low to high includes it.
By their numbers in this assay, from the lowest: compound 1; then compounds 2 and 3 (each within the scatter of the next).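

In this assay, within the data shown here, phenyl in place of neopentyl on a saturated chain carbon bound to an amine nitrogen in a ring gives a 1.6-fold higher number from compound 2 to compound 3 (0.20 log units; within the scatter) and so leaves compound 2 and compound 3 indistinguishable, which the single earlier step could not show for an aromatic ring at this place. Compound 1 stands apart from both, with a 12-fold higher number from compound 1 to compound 3 (1.08 log units; beyond the scatter) alongside a 7.5-fold higher number from compound 1 to compound 2 (0.88 log units; beyond the scatter) in the same assay, so among these three compounds the lowest number belongs to the one with tert-butoxycarbonyl on the amine nitrogen in the ring, and benzyl and 3,3-dimethylbutyl both lie beyond the scatter from it. No measurement at hand explains either the gap to compound 1 or the agreement of compound 2 and compound 3.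

Open, from the compounds shown here alone, is whether the carbonyl of tert-butoxycarbonyl is what matters here, which an acetyl group, a methyl carbamate or a urea on the same nitrogen would test. Also open, going by these compounds, is how this position answers to a free amine hydrogen, or to a benzyl group carrying a carboxylic acid or an amine on its ring.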